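From benzyloxy to (2-fluorobenzyl)oxy in compound 2

A few compounds are considered here, and "the series" means these few. Any claim that something is new, unique, unknown or untested is made for them only; others in the source may bear on it.

Values from a functional assay on GBM3 cells (Homo sapiens) for antiproliferative activity, read by WST assay, with a stated time of 72 h (a higher number here means a weaker inhibitor, a lower number a stronger inhibitor), follow.
Compound 1 `O=C(Nc1ccc(Cl)c(Cl)c1)Nc1cc2ncncc2cc1OCc1ccccc1F` gives > 10000 nM (a limit of the assay)
Compound 2 `O=C(Nc1ccccc1F)Nc1cc2ncncc2cc1OCc1ccccc1` gives 5900 nM
Compound 3 `O=C(Nc1ccc(C(F)(F)F)cc1)Nc1cc2ncncc2cc1OCc1cccc(Cl)c1` gives 5100 nM

In this assay, among the compounds with values here, compound 2 at 5900 nM lies within the scatter of compound 3 at 5100 nM and these are the only two numbers. Compound 1 reports a limit and not a number.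

Compound 4 `O=C(Nc1ccccc1F)Nc1cc2ncncc2cc1OCc1ccccc1F` differs from compound 2 by one change (fluoro in place of hydrogen on an aromatic carbon), fluoro in place of hydrogen on an aromatic carbon, ortho to a large group, so benzyloxy becomes (2-fluorobenzyl)oxy. Within the data shown here, no measured pair isolates this change, so no shift in either direction beyond the scatter is expected in this assay from this change. The estimated step of a 1.0-fold higher number from compound 2 to compound 4 (0.01 log units; within the scatter) is expected to stay within the scatter. Compound 4 is estimated at 6000 nM (expected range 2500 nM to 10000 nM).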

Compound 4, half-maximal inhibitory concentration: 3800 nM
For compound 4 the middle estimate is 1.6-fold (0.20 log units) above the measured one, within the range that was stated.
By their numbers in this assay, from the lowest: compounds 4, 3 and 2 (each within the scatter of the next). At a limit, above all of these: compound 1.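

In this assay, within the data shown here, the single change at this position gives a 1.6-fold lower number from compound 2 to compound 4 (0.19 log units; within the scatter), so (2-fluorobenzyl)oxy and benzyloxy cannot be told apart here. With (2-fluorobenzyl)oxy held constant, 2-fluorophenyl in place of 3,4-dichlorophenyl on the amide-type nitrogen gives an at least 2.6-fold lower number from compound 1 to compound 4 (0.42 log units; beyond the scatter), the only step shown beyond the scatter. Compound 1 reports a limit, so that step is only a bound: the limit of > 10000 nM in this assay, at which 1 of the 4 values shown sits.

On these data alone, it remains open what an amine or a methoxy group in place of this fluoro would give. As far as these compounds go, the effect of this fluoro alongside other groups on the amide-type nitrogen also remains open.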